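Three limits in a row and a fourth compound pending

The source may hold more compounds than are shown below. What is called first, only, known or untested is meant among the compounds shown, and "the series" means these compounds.

In an ADME assay on HCT-116 cells (Homo sapiens) for cytotoxicity, read by MTT assay, with a stated time of 72 h (on this read-out lower numbers stand for stronger inhibition and higher numbers for weaker inhibition), compound 1 `Cc1ccc(NC(=O)c2cccc(/C=C3\CC(=O)N(c4ccccc4)C3=O)c2)cc1` gives > 100000 nM, which is a limit of the assay and not a number.
In this assay compound 2 `Cc1ccc(NC(=O)c2cccc(/C=C3\CC(=O)N(c4ccccc4)C3=O)c2)cc1C` gives > 100000 nM, likewise a limit.
In this assay compound 3 `COc1ccc(NC(=O)c2cccc(/C=C3\CC(=O)N(c4ccccc4)C3=O)c2)c(C)c1` gives > 100000 nM, again a limit.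

All three measured compounds share one core and differ only in the group on the amide-type nitrogen. Every value sits at the limit (the limit of > 100000 nM in this assay, at which 3 of the 3 values shown sit), so none of the steps among them can be read. The change hydrogen in place of methyl on an aromatic carbon gives a step that the two limits leave unreadable from compound 2 to compound 1. The change 4-methoxy-2-methylphenyl in place of 3,4-dimethylphenyl on an amide-type nitrogen gives a step that the two limits leave unreadable from compound 2 to compound 3, and the remaining pair gives a step that the two limits leave unreadable from compound 1 to compound 3. Within these three compounds no ranking is possible.

Compound 4 `COc1ccc(NC(=O)c2cccc(/C=C3\CC(=O)N(c4ccccc4)C3=O)c2)cc1` has not yet been tested in this assay. It differs from compound 3 by hydrogen in place of methyl on an aromatic carbon. Going by the values given here, this is the same kind of change as the one from compound 2 to compound 1, though the surroundings differ: there the leaving methyl sat ortho to a methyl group and meta to a large group, whereas here it sits ortho to a large group and meta to a methoxy group. The expectation for compound 4 rests on compound 3, which gives > 100000 nM, and on the unreadable step that the two limits leave unreadable from compound 2 to compound 1 for the same kind of change. Compound 4 is therefore expected to show a number no higher from compound 3 to compound 4 (the limit leaves the size open) and to sit at 100000 nM, between 30000 nM and 300000 nM, most likely again as a limit.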

Compound 4, half-maximal inhibitory concentration: > 100000 nM
Compound 4: no number, only a limit; the forecaster's own chance of this, stated with the estimate: 80%; the middle value lies on the limit itself.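

In this assay compound 4 gives > 100000 nM, which is a limit and not a number. None of the steps linking compound 4 to compound 1, compound 2 or compound 3 can therefore be read, and the four compounds cannot be ranked: the limit of > 100000 nM in this assay, at which 4 of the 4 values shown sit.

The compounds shown leave open where each true value lies and whether any group on the amide-type nitrogen would give a readable number in this assay.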